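The compounds below may be only part of what the source reports. "The series", "measured", "known", "first", "only" and "open" are said of these compounds alone.

Compound 1 `CC(C)[C@H](C[C@H]1OC(=O)NC1=O)c1ccc(-c2ccc3cccc(F)c3c2)[nH]c1=O`: 0.95 h
Compound 2 `CC(C)(/C=C1\OC(=O)NC1=O)c1ccc(-c2ccc3cccc(F)c3c2)[nH]c1=O`: > 3 h
Compound 3 `O=C1NC(=O)/C(=C/C(c2ccc(-c3ccc4cccc(F)c4c3)[nH]c2=O)C2CC2)O1`: > 3 h

Three compounds sharing one core have been run in an ADME assay on microsomes from liver (Rattus norvegicus) for metabolic stability; a higher number here means that the compound lasts longer, a lower number that the compound disappears faster. In this assay compound 1 gives 0.95 h. For compound 2 the read-out is not a number but a limit of the assay, > 3 h. For compound 3 the read-out is likewise a limit of the assay, > 3 h. Compound 3 therefore stands at the limit of > 3 h in this assay, at which 2 of the 3 values shown sit, and no number separates it from compound 2; only compound 1 returns a half-life that was actually resolved.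

No pair of these compounds differs in a single place, so no measured step is available. The next compound, compound 4 `CCC(CC)C(/C=C1\OC(=O)NC1=O)c1ccc(-c2ccc3cccc(F)c3c2)[nH]c1=O`, follows from compound 3 by one change: pentan-3-yl in place of cyclopropyl on a saturated chain carbon bound to an aromatic carbon and a double-bonded chain carbon. With nothing measured for such a change, the expectation is a step of modest size, if any, in this assay, and a move downward is held slightly more likely than one beyond the scatter upward. Compound 4 is expected to give about 2.5 h, with a plausible range from 0.8 h to 6 h. The step of an at least 1.2-fold lower number from compound 3 to compound 4 (0.07 log units; that floor lies within the scatter) is thus expected to be small, with a fair chance that the assay again returns only a limit.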

Compound 4, half-life: > 3 h
Compound 4 ended at the assay's limit; the forecaster's own chance of this, stated with the estimate: 40%; middle value at least 1.2-fold (0.07 log units) away from the limit.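

In this assay compound 4 gives > 3 h, which is a limit of the assay. Among the compounds shown here, compound 3 also returned a limit, so no step between compound 3 and compound 4 can be read. The compounds shown leave open whether pentan-3-yl in place of cyclopropyl changes the half-life at all.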